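This account rests on a few compounds, and the source may have more. Where it says the series, first, only, none or still open, it means among the compounds named here.

Measured in a functional assay on KYSE-450 cells (Homo sapiens) for inhibition, read by MTT assay, with a stated time of 48 h (on this read-out lower numbers stand for stronger inhibition and higher numbers for weaker inhibition), so far:
compound 1 `CCC/C=C/C(=O)N(Cc1ccc(OC)c(O)c1)c1cc(OC)c(OC)c(OC)c1`: 57 nM
compound 2 `C/C=C/C(=O)N(Cc1ccc(OC)c(C)c1)c1cc(OC)c(OC)c(OC)c1`: 32900 nM
compound 3 `COC(=O)c1cc(CNc2cc(OC)c(OC)c(OC)c2)ccc1OC`: 41100 nM

Compound 1 holds the lowest number of the three; compound 2 lies far higher, beyond the scatter, and compound 3 higher still. Compound 4 `COc1ccc(CN(C(=O)C=C(C)C)c2cc(OC)c(OC)c(OC)c2)cc1O` is the next untested member and differs from compound 1 in one place: 2-methylprop-1-en-1-yl in place of pent-1-en-1-yl on a carbonyl carbon. For the measured compounds named here, no measured pair isolates this change; compound 2 carries a different chain on the carbonyl carbon but also another alteration, so its number cannot be read against compound 1 for this step alone. On the numbers shown, a moderate rise in this assay is expected, beyond the scatter but far short of the gap to compound 2. Compound 4 is therefore estimated at 300 nM (range 60 nM to 2000 nM), an expected step of a 5.3-fold higher number from compound 1 to compound 4 (0.72 log units; beyond the scatter).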

Compound 4, half-maximal inhibitory concentration: 280 nM
Estimate against measurement, compound 4: 1.1-fold (0.03 log units) above, and the stated range covers the measured number.
By their numbers in this assay, from the lowest: compound 1; then compound 4; then compounds 2 and 3 (each within the scatter of the next).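

In this assay, for the compounds shown here, replacing pent-1-en-1-yl with 2-methylprop-1-en-1-yl on the carbonyl carbon gives a 4.9-fold higher number from compound 1 to compound 4 (0.69 log units; beyond the scatter), the first step that isolates a single change. This position therefore accepts a branched chain with one carbon fewer at a modest but real cost. No evidence on hand accounts for the step.

The compounds shown do not separate branching from chain length. Also open, going by these compounds, is how a longer chain such as hept-1-en-1-yl, or a chain ending in an amine, would behave at this carbonyl carbon.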